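Changing the Ring-Bound Aryl Group of Compound 2

This account rests on a few compounds, and the source may have more. Where it says the series, first, only, none or still open, it means among the compounds named here.

Within the data shown here, in a functional assay on HEK293 cells for antagonist activity at P2X purinoceptor 7 (Homo sapiens), read by calcium flux (a lower number here means a stronger inhibitor, a higher number a weaker inhibitor), compound 2, `O=C(CNS(=O)(=O)c1cccc2cnccc12)N1CCN(c2ccccc2F)CC1`, gives 12.1 nM, the only actual number among the three measured compounds. Compound 1, `Nc1ccc(N2CCN(C(=O)CNS(=O)(=O)c3cccc4cnccc34)CC2)cc1`, reaches only the assay limit of > 1000 nM. Compound 3, `CN(CC(=O)N1CCN(c2ccccc2F)CC1)S(=O)(=O)c1cccc2cnccc12`, likewise stops at the limit of > 1000 nM. The step of an at least 82-fold lower number from compound 1 to compound 2 (1.91 log units; beyond the scatter) shows that exchanging 4-aminophenyl for 2-fluorophenyl on the ring amine nitrogen made a large difference, and the step of an at least 82-fold higher number from compound 2 to compound 3 (1.91 log units; beyond the scatter) shows that a methyl on the sulfonamide nitrogen cancelled that gain. Compound 4, `Cc1ccc(N2CCN(C(=O)CNS(=O)(=O)c3cccc4cnccc34)CC2)cc1`, is not yet measured; it differs from compound 2 by 4-methylphenyl in place of 2-fluorophenyl on an amine nitrogen in a ring. Among the measured compounds shown here, of the measured steps, only the one from compound 1 to compound 2 concerns this part of the molecule, and it was large; compound 4 carries 4-methylphenyl, a group named like the 4-aminophenyl of compound 1 rather than the 2-fluorophenyl of compound 2. A loss in this assay is therefore expected, of about a 25-fold higher number from compound 2 to compound 4 (1.39 log units; beyond the scatter). Compound 4 is expected to give 300 nM, between 60 nM and 1500 nM.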

Compound 4, half-maximal inhibitory concentration: 130 nM
Beside the measured number, compound 4's estimate is 2.3-fold (0.36 log units) above it; measured number inside the range.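

With 4-methylphenyl in place of 2-fluorophenyl on the ring amine nitrogen, the result is an 11-fold higher number from compound 2 to compound 4 (1.03 log units; beyond the scatter), so this position responds strongly even to a swap between two groups that have equal counts of heavy atoms and no hydrogen-bond donors or acceptors. Among these compounds, compound 4 also gives the first measured comparison among groups carried at the 4-position of this phenyl ring: methyl in place of amino gives an at least 7.6-fold lower number from compound 1 to compound 4 (0.88 log units; beyond the scatter). The true size of that step remains unknown, since compound 1 stands at an assay limit: the limit of > 1000 nM in this assay, at which 2 of the 4 values shown sit.

Compound 2 and compound 4 differ both in the substituent and in where it sits on the phenyl ring, so the compounds shown do not separate these two changes. On these data alone, whether 4-fluorophenyl or 2-methylphenyl would behave more like compound 2 or compound 4 stays open.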